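The source may hold more compounds than are shown below. What is called first, only, known or untested is meant among the compounds shown, and "the series" means these compounds.

Measured so far in an ADME assay on microsomes from liver (Rattus norvegicus) for metabolic stability; a lower number here means that the compound disappears faster, a higher number that the compound lasts longer:
compound 1 `CC(C)C(c1nnc[nH]1)c1ccc(-c2ccc3cccc(F)c3c2)[nH]c1=O`: 0.552 h
compound 2 `CC(C)C(/C=C1/CCNC1=O)c1ccc(-c2ccc3cccc(F)c3c2)[nH]c1=O`: 0.06 h
compound 3 `CCC(CC)(c1nnc[nH]1)c1ccc(-c2ccc3cccc(F)c3c2)[nH]c1=O`: 0.925 h

Compound 3 has the highest number of the three in this assay, but its gap to compound 1 lies within the usual scatter of this kind of measurement, so these two cannot be ranked against each other; only compound 2 sits clearly lower. Compound 4 `CCC(CC)(c1nnc[nH]1)c1ccc(-c2ccc3cc(F)cc(F)c3c2)[nH]c1=O` has not yet been measured. It differs from compound 3 in one place: fluoro in place of hydrogen on an aromatic carbon. For the measured compounds named here, the only measured step, a 9.2-fold lower number from compound 1 to compound 2 (0.96 log units; beyond the scatter), concerns a different part of the molecule and says nothing about adding a second fluoro group to the fused ring system. With no comparable change among the measured compounds, the expectation for this assay is a step that stays within the scatter, in either direction: a 1.2-fold higher number from compound 3 to compound 4 (0.08 log units; within the scatter). Compound 4 is therefore estimated at 1.1 h, with a range from 0.5 h to 2.5 h.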

Compound 4, half-life: 1.26 h
Compound 4: middle estimate off by 1.1-fold (0.06 log units), on the low side; measured number inside the range.
By their numbers in this assay, from the lowest: compound 2; then compounds 1, 3 and 4 (each within the scatter of the next, the first and the last beyond it).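

In this assay, fluoro in place of hydrogen on an aromatic carbon of the fused ring system gives a 1.4-fold higher number from compound 3 to compound 4 (0.13 log units; within the scatter), so this assay cannot tell compound 3 and compound 4 apart. For the compounds shown here, this is the first measured change on that ring system, and it shows that a second fluoro group at this carbon, meta to the first, can be added without a drop in half-life that stands out from the scatter. Nothing measured here explains this outcome.

Still open, from the compounds shown here alone, is whether a chloro, methoxy or nitrile group on this same carbon would give a step beyond the scatter. Also open, going by these compounds, is whether fluoro on another carbon of this ring, or the same change in compound 1, would behave as it does here.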